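Capping the Amine: From Compound 2 to Compound 4

A few compounds are considered here, and "the series" means these few. Any claim that something is new, unique, unknown or untested is made for them only; others in the source may bear on it.

Of the compounds shown here, three of one series have been measured in an assay for inhibition of 15-hydroxyprostaglandin dehydrogenase [NAD(+)] (Homo sapiens), read by fluorescence, with a stated time of 15 min, in the presence of a further agent that is not named here; on this read-out higher numbers stand for weaker inhibition and lower numbers for stronger inhibition. Compound 1 `CCC[S+]([O-])c1sc2ncccc2c1N` gives 151 nM in this assay. Compound 2 `CCCC[S+]([O-])c1sc2nc(-c3nccs3)cc(-c3ccc(CN)cc3)c2c1N` gives 11.5 nM in this assay, the lowest of the two numbers shown, with compound 1 standing clearly higher, beyond the usual scatter. Compound 3 `Nc1c(C(=O)O)sc2nc(-c3cccs3)cc(-c3ccccc3)c12` is reported only as a limit: in this assay compound 3 gives > 7500 nM, which is a limit of the assay rather than a number (the limit of > 7500 nM in this assay, at which 1 of the 3 values shown sits).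

Compound 4 `CCCC[S+]([O-])c1sc2nc(-c3nccs3)cc(-c3ccc(CNS(C)(=O)=O)cc3)c2c1N` has not yet been measured. It differs from compound 2 in one place: methylsulfonyl in place of hydrogen on an amine nitrogen. Among the compounds with values here, no pair of measured compounds shows this change, so nothing in the data fixes its size or direction. The change keeps the whole of compound 2 and adds a methylsulfonyl on the amine nitrogen whose other neighbour is a saturated chain carbon.

The step in this assay from compound 2 to compound 4 is expected to be small, a 1.7-fold higher number from compound 2 to compound 4 (0.24 log units; within the scatter), in the direction of a slightly higher number, and possibly no step beyond the scatter at all. Compound 4 is therefore estimated at 20 nM in this assay, within a range of 5 nM to 80 nM.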

Compound 4, half-maximal inhibitory concentration: 4.6 nM
Estimate against measurement, compound 4: 4.3-fold (0.64 log units) above, and the stated range ends above it.
By their numbers in this assay, from the lowest: compound 4; then compound 2; then compound 1. At a limit, above all of these: compound 3.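

In this assay, methylsulfonyl in place of hydrogen on the amine nitrogen goes with a 2.5-fold lower number from compound 2 to compound 4 (0.40 log units; beyond the scatter), a modest step that nonetheless lies beyond the scatter. Within the data shown here, this gives the first reading at this position: the hydrogen on this nitrogen, whose other neighbour is a saturated chain carbon, is not needed to keep the number low, and aminomethyl can give way to the larger (methanesulfonamido)methyl without any loss on this read-out, though this rests on a single pair of compounds. Nothing measured among these compounds bears on what lies behind the step.

An acetyl or a methyl on the same amine nitrogen would help to tell whether the lower number belongs to the methylsulfonyl in particular or comes with any group at this place, and a longer sulfonyl group such as ethylsulfonyl would show how much size this position accepts. On these data alone, compound 1 and compound 3 differ from compound 4 in more than one place, so they say nothing about this change, and whether it would carry over to a different chain on the sulfoxide remains open.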